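This account rests on a few compounds, and the source may have more. Where it says the series, first, only, none or still open, it means among the compounds named here.

Measured so far in a functional assay on BMDM cells (Mus musculus, strain C57BL/6) for inhibition, with a stated time of 2 days; a lower number here means a stronger inhibitor, a higher number a weaker inhibitor:
Compound 1 `CCOC(=O)c1sc(NC(=O)Cn2cc(-c3ccc(OC)cc3)nn2)nc1C` gives 2330 nM.
Compound 2 `COc1ccc(-c2cn(CC(=O)Nc3cc(C)on3)nn2)cc1` gives only a limit, > 30000 nM.

Compound 2 stands at the edge of what this assay can report: its result is not a number but a limit, (the limit of > 30000 nM in this assay, at which 1 of the 2 values shown sits), so its true value could lie anywhere beyond that point. Among the compounds with values here, compound 1 is the only compound here that returns a measurable number in this assay, and that number is 2330 nM.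

Compound 3 `COc1ccc(-c2cn(CC(=O)Nc3nc(C)cs3)nn2)cc1` has not yet been measured. It differs from compound 2 in one place: 4-methyl-1,3-thiazol-2-yl in place of 5-methyl-1,2-oxazol-3-yl on an amide-type nitrogen. Within the data shown here, no measured pair shows this exact change, so its size cannot be read off from the data and can only be expected. A step toward stronger inhibition seems plausible, and the expected step from compound 2 to compound 3 is an at least 3.0-fold lower number from compound 2 to compound 3 (0.47 log units; beyond the scatter), though with compound 2 at a limit the starting point itself is uncertain. Compound 3 is therefore estimated at 10000 nM in this assay, with a range from 3000 nM to 30000 nM.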

Compound 3, half-maximal inhibitory concentration: 3890 nM
Compound 3: middle estimate off by 2.6-fold (0.41 log units), on the high side; low and high end bracket the measured number.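

On the amide-type nitrogen, 4-methyl-1,3-thiazol-2-yl in place of 5-methyl-1,2-oxazol-3-yl turns a limit into a measurable number in this assay, with an at least 7.7-fold lower number from compound 2 to compound 3 (0.88 log units; beyond the scatter), so the group at this position clearly matters. The full size of that step stays unknown, as compound 2 gives only a limit of the assay and not a number: the limit of > 30000 nM in this assay, at which 1 of the 3 values shown sits.

Hydrogen in place of ethoxycarbonyl on an aromatic carbon gives a 1.7-fold higher number from compound 1 to compound 3 (0.22 log units; within the scatter), so the two compounds cannot be told apart in this assay, and the ethoxycarbonyl group is not needed for a measurable number here.

On these data alone, it remains open whether a carboxylic acid or an amine on that same aromatic carbon would move the number beyond the scatter, and whether a longer chain such as propyl in place of the methyl would do so. Within the data shown here, only two groups on the amide-type nitrogen can be compared so far, so how a phenyl group there would fare against 4-methyl-1,3-thiazol-2-yl is also unknown.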